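This account rests on a few compounds, and the source may have more. Where it says the series, first, only, none or still open, it means among the compounds named here.

In a functional assay on NCI-H292 cells (Homo sapiens) for cytotoxicity, read by MTT assay, with a stated time of 72 h, tested at 1.25 ug/mL (on this read-out higher numbers stand for more inhibition of growth at the one concentration tested and lower numbers for less inhibition of growth), compound 2 `O=C1NC(=S)/C(=C/c2ccc(Br)cc2)S1` gives 1.1%. That number cannot be told apart from those of its two measured relatives: compound 1 `O=C1NC(=S)/C(=C/c2ccc(Cl)cc2)S1` gives 10% and compound 3 `O=C1NC(=S)/C(=C/c2ccccc2Cl)S1` gives 10.6%, all within the scatter of one another. Compound 4 `O=C1NC(=S)/C(=C/c2ccc(F)cc2)S1` departs from compound 2 by fluoro in place of bromo on an aromatic carbon, which is fluoro in place of bromo on an aromatic carbon. Among the measured compounds shown here, only one measured step bears on this, bromo in place of chloro on an aromatic carbon, and a number 8.9 percentage points lower from compound 1 to compound 2 (within the scatter) stays within the scatter. For the measured compounds named here, no measured step involves fluoro. No change beyond the scatter is therefore expected in this assay, and the expected step is a number 5.9 percentage points higher from compound 2 to compound 4 (within the scatter). Compound 4 is estimated at 7%, with an expected range of 0% to 18%.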

Compound 4, percent growth inhibition at one concentration: 7.32%
For compound 4 the middle estimate is 0.3 percentage points below the measured one; the range from low to high includes it.
By their numbers in this assay, from the lowest: compounds 2, 4, 1 and 3 (each within the scatter of the next).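

In this assay, among the compounds shown here, the earlier compounds compared only bromo and chloro at this position, and fluoro now extends that comparison: fluoro in place of bromo gives a number 6.2 percentage points higher from compound 2 to compound 4 (within the scatter), and fluoro in place of chloro gives a number 2.7 percentage points lower from compound 1 to compound 4 (within the scatter). Compounds 1, 2 and 4 therefore cannot be told apart, and exchanging these three halogens here shows no effect beyond the scatter. Nothing available explains the small differences among them. Going by these compounds, whether an amine or a carboxylic acid at this position would give a number beyond the scatter remains open.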